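The source may hold more compounds than are shown below. What is called first, only, known or untested is meant among the compounds shown, and "the series" means these compounds.

Measured compounds:
- compound 1 `CN1CCN(CCCCCCn2c3c(c4ccccc42)C(=O)c2c[n+]([O-])c4ccccc4c2C3=O)CC1` — in a functional assay on HCT-116 cells (Homo sapiens) for cytotoxicity, read by MTT assay, with a stated time of 72 h (on this read-out higher numbers stand for weaker inhibition and lower numbers for stronger inhibition), compound 1 gives 2900 nM
- compound 2 `O=C1c2c[n+]([O-])c3ccccc3c2C(=O)c2c1c1ccccc1n2Cc1cn([C@H]2C[C@H](O)[C@@H](CO)O2)nn1` — compound 2 gives 120 nM
- compound 3 `O=C1c2c[n+]([O-])c3ccccc3c2C(=O)c2c1c1ccccc1n2Cc1cn([C@@H]2C[C@H](O)[C@@H](CO)O2)nn1` — compound 3 gives 50 nM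

Compound 1 stands highest of the three numbers, meaning the weakest inhibition shown. Within the data shown here, the only measured step, a 2.4-fold lower number from compound 2 to compound 3 (0.38 log units; beyond the scatter), rests on the fact that compounds 2 and 3 differ only in the configuration as drawn and concerns the sugar-bearing side chain, not the side chain changed here.

Compound 4 `O=C1c2c[n+]([O-])c3ccccc3c2C(=O)c2c1c1ccccc1n2CCCCN1CCCCC1` differs from compound 1 by piperidin-1-yl in place of 2-(4-methylpiperazin-1-yl)ethyl on a saturated chain carbon, four bonds along the chain from an aromatic nitrogen. Among the measured compounds shown here, no measured step bears on a swap of this kind, so the expectation can only be that compound 4 stays near compound 1, with no step beyond the scatter expected in this assay. The estimated step is a 1.5-fold lower number from compound 1 to compound 4 (0.16 log units; within the scatter). Compound 4 is therefore estimated at 2000 nM, with a range from 500 nM to 8000 nM.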

Compound 4, half-maximal inhibitory concentration: 200 nM
Compound 4: the middle estimate sits 10-fold (1.00 log units) above what was measured; the whole stated range lies above it.
By their numbers in this assay, from the lowest: compound 3; then compounds 2 and 4 (each within the scatter of the next); then compound 1.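

In this assay, piperidin-1-yl in place of 2-(4-methylpiperazin-1-yl)ethyl gives a 15-fold lower number from compound 1 to compound 4 (1.16 log units; beyond the scatter) on the same core. The number at this place on the chain therefore depends strongly on the group it carries. Ring and chain length change together in this swap, so the two cannot be separated here.

On these data alone, whether morpholin-4-yl, or 4-methylpiperazin-1-yl on a shorter chain, would give a number like that of compound 4 stays open. Nothing measured here explains why the number falls.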